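Side-chain variation on the saturated chain carbon

The source may report more compounds than this note shows. Statements on the series, on what has been measured and on what is new or still open speak of the compounds shown alone.

Compound 1 `CNC(=O)C[C@@H]1C[C@@H](c2ccc(Cl)c(Cl)c2)[C@H](NC(=O)c2cc(-c3c(Cl)cnn3C)c(Cl)o2)CN1` and compound 2 `CN(C)CC[C@@H]1C[C@@H](c2ccc(Cl)c(Cl)c2)[C@H](NC(=O)c2cc(-c3c(Cl)cnn3C)c(Cl)o2)CN1` share one core and differ only on a saturated chain carbon bound to a saturated ring carbon. In a functional assay on OVCAR-8 cells (Homo sapiens) for antiproliferative activity (on this read-out lower numbers stand for stronger inhibition and higher numbers for weaker inhibition), compound 1 gives 1130 nM. In this assay compound 2 gives 1510 nM; compound 2 thus stands as the higher of the two numbers shown, but the step of a 1.3-fold higher number from compound 1 to compound 2 (0.13 log units; within the scatter) places that gap within the scatter. Compound 3 `Cn1ncc(Cl)c1-c1cc(C(=O)N[C@@H]2CN[C@H](CC(=O)NCCO)C[C@H]2c2ccc(Cl)c(Cl)c2)oc1Cl` is not yet measured and differs from compound 2 by (2-hydroxyethyl)carbamoyl in place of (dimethylamino)methyl on a saturated chain carbon bound to a saturated ring carbon. Within the data shown here, the one step that bears on this change is a 1.3-fold higher number from compound 1 to compound 2 (0.13 log units; within the scatter), which exchanged methylcarbamoyl for (dimethylamino)methyl at the same place without moving the number beyond the scatter; the new change restores a carbamoyl, now the (2-hydroxyethyl)carbamoyl. No step beyond the scatter is therefore expected, and the estimate for compound 3 is a 1.3-fold lower number from compound 2 to compound 3 (0.10 log units; within the scatter). For compound 3 the expected value in this assay is 1200 nM, with a range of 450 nM to 3200 nM.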

Compound 3, half-maximal inhibitory concentration: 1450 nM
Compound 3: middle estimate off by 1.2-fold (0.08 log units), on the low side; measured number inside the range.
By their numbers in this assay, from the lowest: compounds 1, 3 and 2 (each within the scatter of the next).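

In this assay the step of a 1.0-fold lower number from compound 2 to compound 3 (0.02 log units; within the scatter) shows that (2-hydroxyethyl)carbamoyl can replace (dimethylamino)methyl on a saturated chain carbon bound to a saturated ring carbon without a shift beyond the scatter, even though the entering group is larger and adds oxygen atoms and hydrogen-bond donors. The step of a 1.3-fold higher number from compound 1 to compound 3 (0.11 log units; within the scatter), with hydroxymethyl in place of hydrogen on a saturated chain carbon bound to an amide-type nitrogen, also stays within the scatter, so the three side chains cannot be told apart on this read-out. Nothing available accounts for this flat reading.

Still open, from the compounds shown here alone, is whether a carboxylic acid, a primary amine or a longer chain at this place would move the number beyond the scatter. The same question holds for a ring-bearing side chain such as morpholine.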